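This account rests on a few compounds, and the source may have more. Where it says the series, first, only, none or still open, it means among the compounds named here.

Within the data shown here, in a functional assay on HCT-15 cells (Homo sapiens) (a lower number here means that less compound is needed, a higher number that more compound is needed for the effect), compound 1 (`COc1cc(C2OC(c3ccc(N)c(C)c3)=NN2C(C)=O)cc(OC)c1OC`) gives 0.042 uM, while compound 2 (`CCCCNC(=O)c1c(OC)cc(C2OC(c3ccc(N)c(C)c3)=NN2C(C)=O)cc1OC`) gives 178 uM, the higher of the two numbers measured so far. Among the measured compounds shown here, the one measured step is a 4200-fold higher number from compound 1 to compound 2 (3.63 log units; beyond the scatter). It is large, and it comes with butylcarbamoyl in place of methoxy on an aromatic carbon.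

Compound 3 (`COC(=O)c1c(OC)cc(C2OC(c3ccc(N)c(C)c3)=NN2C(C)=O)cc1OC`) has not yet been measured. It differs from compound 2 by methoxy in place of butylamino on a carbonyl carbon, which turns butylcarbamoyl into methoxycarbonyl: methoxy in place of butylamino on a carbonyl carbon.

The measured step bears on this change only in part, since methoxycarbonyl removes the butylamino but does not restore the methoxy of compound 1. With compound 2 at 178 uM and compound 1 at 0.042 uM, compound 3 is expected to fall somewhere between them, and nothing measured shows where. A sizeable move towards a lower number is therefore expected, estimated as a 22-fold lower number from compound 2 to compound 3 (1.35 log units; beyond the scatter). For compound 3, the estimate is 8 uM, with an expected range from 0.4 uM to 120 uM.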

Compound 3, concentration for half-maximal effect: 0.28 uM
For compound 3 the middle estimate is 29-fold (1.46 log units) above the measured one, outside the stated range (below it).
By their numbers in this assay, from the lowest: compound 1; then compound 3; then compound 2.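

Replacing butylamino with methoxy on the carbonyl carbon in this assay gives a 640-fold lower number from compound 2 to compound 3 (2.80 log units; beyond the scatter) and so removes most of the loss seen with butylcarbamoyl. This shows that a carbonyl at this aromatic position does not by itself bring the very high number of compound 2; what is attached to that carbonyl makes a large difference. Methoxycarbonyl still does not fully match the original methoxy, since the listed change gives a 6.7-fold higher number from compound 1 to compound 3 (0.82 log units; beyond the scatter) and this modest step lies beyond the scatter.

Butylamino and methoxy differ both in the atom joined to the carbonyl carbon and in the length of the chain, so these compounds cannot separate those two features. A methylamino group would keep the nitrogen with a shorter chain, a butoxy group would keep the oxygen with a longer chain, and a carboxylic acid at the same place would show how the series responds without either chain.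

No measurement shown here explains why these groups give such different numbers.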